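The source may report more compounds than this note shows. Statements on the series, on what has been measured and on what is new or still open speak of the compounds shown alone.

In a functional assay on MOLT-4 cells (Homo sapiens) for inhibition, read by sulforhodamine B assay, with a stated time of 48 h (a higher number here means a weaker inhibitor of growth, a lower number a stronger inhibitor of growth), compound 1 `Cc1ccc(NC(=O)/C=C/c2ccccc2)c(C(N)=O)c1` gives 3560 nM, and compound 2 `NC(=O)c1cc(Br)ccc1NC(=O)/C=C/c1ccccc1` gives 1860 nM. For the measured compounds named here, these are the only two numbers available, and compound 2 stands within the scatter of compound 1, so the two cannot be ranked. Going by the values given here, the single measured step, a 1.9-fold lower number from compound 1 to compound 2 (0.28 log units; within the scatter), put bromo in place of methyl on an aromatic carbon. Compound 3 `NC(=O)c1cc(I)ccc1NC(=O)/C=C/c1ccccc1` has not yet been measured. It differs from compound 2 by one exchange on that same carbon, meta to a carbamoyl group and para to a large group: iodo in place of bromo on an aromatic carbon. Among the compounds with values here, no measured compound carries iodo, so the data offer no direct precedent for this group. Within the data shown here, the only guide is a 1.9-fold lower number from compound 1 to compound 2 (0.28 log units; within the scatter), a change at this carbon that stayed within the scatter. On that evidence, no step beyond the scatter is expected in this assay, and neither direction is favoured. The expected change is small, a 1.0-fold lower number from compound 2 to compound 3 (0.01 log units; within the scatter). For compound 3 the estimated value is 1800 nM, with an expected range from 750 nM to 4300 nM.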

Compound 3, concentration for 50% growth inhibition: 202 nM
Beside the measured number, compound 3's estimate is 8.9-fold (0.95 log units) above it, and the stated range ends above it.
By their numbers in this assay, from the lowest: compound 3; then compounds 2 and 1 (each within the scatter of the next).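

In this assay, the carbon meta to a carbamoyl group proves sensitive to what it carries: iodo in place of bromo gives a 9.2-fold lower number from compound 2 to compound 3 (0.96 log units; beyond the scatter), whereas bromo in place of methyl had produced no change beyond the scatter. Iodo in place of methyl at this carbon gives an 18-fold lower number from compound 1 to compound 3 (1.25 log units; beyond the scatter), making compound 3 the strongest inhibitor of growth of the three and showing that this carbon can shift the number far more than the earlier pair suggested; the shift belongs to iodo alone among these groups, not to halogens in general, since compound 2, which carries bromo, cannot be told apart from compound 1, which carries methyl. Nothing available bears on why exchanging one heavy atom for another at this carbon has such an effect.

The compounds shown leave open how chloro, fluoro, trifluoromethyl or ethynyl on this carbon would compare with iodo. From the compounds shown here alone, all three compounds also keep the carbamoyl group, so it remains open whether the low number of compound 3 would survive with a carboxylic acid or a nitrile in its place.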